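The compounds below may be only part of what the source reports. "The series", "measured", "known", "first", "only" and "open" are said of these compounds alone.

Measured compounds:
compound 1 `O=C(NCCCOc1ccc2[nH]c(=O)ccc2c1)N(C1CC1)[C@@H]1CCCC[C@H]1O` with 100%; 100% (2 entries)
compound 2 `O=C(NCCCOc1ccc2nc(O)ccc2c1)N(C1CC1)[C@@H]1CCCCC[C@H]1O` with 44%

Compound 1 `O=C(NCCCOc1ccc2[nH]c(=O)ccc2c1)N(C1CC1)[C@@H]1CCCC[C@H]1O` was tested twice in a functional assay on the whole organism for inhibition, with Mus musculus as the target, at a dose of 30 mg/kg by the oral route (on this read-out lower numbers stand for less inhibition and higher numbers for more inhibition at the one dose given (going by the name of the read-out)), and gave 100%; 100% (2 entries) both times. Compound 2 `O=C(NCCCOc1ccc2nc(O)ccc2c1)N(C1CC1)[C@@H]1CCCCC[C@H]1O` gave 44% in this assay, the lower of the two measured values; beyond that single number there is only a further entry for compound 2 without a value, so its position rests on one measurement. Compound 3 `CCCCO[C@H]1CCCC[C@@H]1N(C(=O)NCCCOc1ccc2nc(O)ccc2c1)C1CC1` has not yet been measured. Compound 3 differs from compound 2 in one place: 2-butoxycyclohexyl in place of 2-hydroxycycloheptyl on an amide-type nitrogen. Going by the values given here, no measured pair isolates this change, so its effect is not known from the data. The expected step is a number 4 percentage points lower from compound 2 to compound 3 (within the scatter), a small shift that the usual scatter could cover. Compound 3 is accordingly expected to give about 40% in this assay, within a range from 10% to 75%.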

Compound 3, a percentage reported as inhibition, in the whole organism at one dose (the size of the read-out at that dose, not a potency): 33%
Beside the measured number, compound 3's estimate is 7 percentage points above it, within the range that was stated.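

In this assay, replacing 2-hydroxycycloheptyl with 2-butoxycyclohexyl on the amide-type nitrogen gives a number 11 percentage points lower from compound 2 to compound 3 (beyond the scatter), the first step measured at this position. It shows that the read-out responds to this change, yet compound 3, which has no hydrogen-bond donor in this group, still gives 33% rather than losing all inhibition at the one dose given. Nothing available explains this step.

The ring size and the substituent on oxygen change together here, so the compounds shown leave open how much of the step belongs to each. Also open, on these data alone, is how a 2-methoxycyclohexyl or 2-aminocyclohexyl group on this nitrogen would read in this assay.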